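Aryl variation at the amine end of the sulfonamide series

A few compounds are considered here, and "the series" means these few. Any claim that something is new, unique, unknown or untested is made for them only; others in the source may bear on it.

Measured so far in a functional assay on BE(2)-C cells (Homo sapiens) for inhibition, read by MTT assay, with a stated time of 72 h; on this read-out higher numbers stand for weaker inhibition of growth and lower numbers for stronger inhibition of growth:
compound 1, `O=S(=O)(NCCCNCc1ccccc1Cl)c1cc(C(F)(F)F)cc(C(F)(F)F)c1`, gives 15000 nM
compound 2, `O=S(=O)(NCCCNCc1ccc(Cl)c(C(F)(F)F)c1)c1cc(C(F)(F)F)cc(C(F)(F)F)c1`, gives 8600 nM
compound 3, `O=S(=O)(NCCCNCc1cccc2ccccc12)c1cc(C(F)(F)F)cc(C(F)(F)F)c1`, gives 2700 nM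

Compound 1 has the highest number of the three. Its nearest neighbour is compound 2: a 1.7-fold lower number from compound 1 to compound 2 (0.24 log units; within the scatter). The furthest is compound 3: a 5.6-fold lower number from compound 1 to compound 3 (0.74 log units; beyond the scatter), and the same direction holds between the other pair: a 3.2-fold lower number from compound 2 to compound 3 (0.50 log units; beyond the scatter).

Compound 4, `O=S(=O)(NCCCNCc1cccc(Cl)c1)c1cc(C(F)(F)F)cc(C(F)(F)F)c1`, is not yet measured in this assay. It differs from compound 1 as follows: 3-chlorophenyl in place of 2-chlorophenyl on a saturated chain carbon bound to an amine nitrogen. For the measured compounds named here, no measured step makes this particular exchange. The two steps that touch the same place both swap 2-chlorophenyl for a different group: the step to compound 2 stays within the scatter, the step to compound 3 is modest. The change to compound 4 keeps the same atoms and only rearranges them, so the expectation is no step beyond the scatter, with the expected step being a 1.3-fold lower number from compound 1 to compound 4 (0.10 log units; within the scatter). Compound 4 is therefore estimated at 12000 nM, with a range from 5000 nM to 30000 nM.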

Compound 4, concentration for 50% growth inhibition: 6900 nM
Compound 4: the middle estimate sits 1.7-fold (0.24 log units) above what was measured, and the stated range covers the measured number.
By their numbers in this assay, from the lowest: compound 3; then compounds 4, 2 and 1 (each within the scatter of the next, the first and the last beyond it).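

In this assay, for the compounds shown here, the exchange of 2-chlorophenyl for 3-chlorophenyl is a modest step on its own (a 2.2-fold lower number from compound 1 to compound 4 (0.34 log units; beyond the scatter)), so at this position a rearrangement of the same atoms is enough to change the read-out, something the earlier steps, which all changed the atoms as well, could not show. The 3-chlorophenyl group also sits within the scatter of the 4-chloro-3-(trifluoromethyl)phenyl group (a 1.2-fold lower number from compound 2 to compound 4 (0.10 log units; within the scatter)), while naphthalen-1-yl keeps a modest edge over it (a 2.6-fold higher number from compound 3 to compound 4 (0.41 log units; beyond the scatter)). Nothing at hand accounts for the difference between the two chlorophenyl groups.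

The compounds shown leave open how 4-chlorophenyl compares with these two chlorophenyl isomers. They also leave open whether naphthalen-2-yl holds the level of naphthalen-1-yl on the shared core.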